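Aryl-piperazine amides: repositioning a methyl on the aryl ring

The compounds below may be only part of what the source reports. "The series", "measured", "known", "first", "only" and "open" are said of these compounds alone.

Measured so far:
compound 1, `Cc1ccc(N2CCN(C(=O)c3oc(C)nc3-c3ccccc3)CC2)c(C)c1` — 101 nM
compound 2, `COc1cc(OC)cc(N2CCN(C(=O)c3sc(C)nc3-c3ccccc3F)CC2)c1` — 96.8 nM

In a functional assay on HL-60 cells (Homo sapiens) for inhibition, read by MTT assay, with a stated time of 72 h (on this read-out higher numbers stand for weaker inhibition and lower numbers for stronger inhibition), compound 1 gives 101 nM, and compound 2 gives 96.8 nM; the two numbers lie within the scatter of each other, so compound 1 stands level with compound 2 in this assay. Compound 3, `Cc1nc(-c2ccccc2)c(C(=O)N2CCN(c3ccc(C)c(C)c3)CC2)o1`, is not yet measured. It differs from compound 1 in one place: 3,4-dimethylphenyl in place of 2,4-dimethylphenyl on an amine nitrogen in a ring. Within the data shown here, no step between measured compounds is available to size this change, so the expectation rests on compound 1 alone, and the step from compound 1 to compound 3 is expected to stay within the scatter, a 1.1-fold higher number from compound 1 to compound 3 (0.04 log units; within the scatter). Compound 3 is therefore estimated at 110 nM, with a range from 45 nM to 280 nM.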

Compound 3, half-maximal inhibitory concentration: 43 nM
Estimate against measurement, compound 3: 2.6-fold (0.41 log units) above, outside the stated range (below it).
By their numbers in this assay, from the lowest: compound 3; then compounds 2 and 1 (each within the scatter of the next).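

In this assay, 3,4-dimethylphenyl in place of 2,4-dimethylphenyl on an amine nitrogen in a ring gives a 2.3-fold lower number from compound 1 to compound 3 (0.37 log units; beyond the scatter). Among these compounds, the two groups hold the same atoms, so this position registers the placement of a methyl alone, which the earlier compounds could not show. Nothing at hand accounts for the step.

Still open, as far as these compounds go, is whether a chlorine atom, an ethyl group or a carboxylic acid at this position would follow the same course. From the compounds shown here alone, whether the step carries over to the core of compound 2 also remains unknown.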